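Series notes: replacing benzamido with fluoro

A few compounds are considered here, and "the series" means these few. Any claim that something is new, unique, unknown or untested is made for them only; others in the source may bear on it.

In an ADME assay on KB cells (Homo sapiens) for cytotoxicity, read by MTT assay, with a stated time of 72 h (on this read-out lower numbers stand for stronger inhibition and higher numbers for weaker inhibition), compound 1 `COc1ccc(C2=C(c3cc(OC)c(OC)c(OC)c3)C(=O)C(O)C2)cc1NC(=O)c1ccccc1` gives > 100 ug/mL, which is a limit of the assay and not a number. Compound 2 `COc1ccc(C2=C(c3cc(OC)c(OC)c(OC)c3)C(=O)CC2O[SiH2]C(C)(C)C)cc1OC` gives > 100 ug/mL, again a limit and not a number. Compound 1 therefore has no measured potency to rank, and the data so far amount to the limit of > 100 ug/mL in this assay, at which 2 of the 2 values shown sit.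

Compound 3 `COc1ccc(C2=C(c3cc(OC)c(OC)c(OC)c3)C(=O)C(O)C2)cc1F` keeps the core of compound 1 but has fluoro in place of benzamido on an aromatic carbon, ortho to a methoxy group: fluoro in place of benzamido on an aromatic carbon. Going by the values given here, no measured pair tests this change, so the size of any effect remains open. With a limit as the starting point, only a move toward stronger inhibition could appear as a number, although another limit reading remains possible. The expected step, an at least 100-fold lower number from compound 1 to compound 3 (2.00 log units; beyond the scatter), is toward stronger inhibition and carries wide uncertainty. In this assay, the estimate for compound 3 is 1 ug/mL, with the value expected between 0.01 ug/mL and 50 ug/mL.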

Compound 3, half-maximal inhibitory concentration: 4.5 ug/mL
Compound 3: the middle estimate sits 4.5-fold (0.65 log units) below what was measured, within the range that was stated.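

The change of fluoro in place of benzamido on an aromatic carbon gives an at least 22-fold lower number from compound 1 to compound 3 (1.34 log units; beyond the scatter) in this assay, a step beyond the scatter and the first one readable in the series. Before compound 3, the series offered no number to compare, only a shared limit: the limit of > 100 ug/mL in this assay, at which 2 of the 3 values shown sit. This place, ortho to a methoxy group, is now shown to matter for the read-out, but the step has a limit as its starting point and fixes only a minimum size, and the change removes the amide and its aromatic ring together, leaving the two parts unseparated.

Still open, on these data alone, is whether fluoro itself contributes or the step reflects only the loss of benzamido, a question that a compound with an amine, chlorine or plain hydrogen at this place, on the core of compound 1, would address. The role of the hydroxyl on the shared core also remains open, with no pair shown that changes it alone.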